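A 4-methylphenyl group on the ring nitrogen

The source may report more compounds than this note shows. Statements on the series, on what has been measured and on what is new or still open speak of the compounds shown alone.

Compound 1 `COC(=O)CC/C(C)=C/Cc1c(OC)c(C)c2c(c1OCC#CCN1CCN(c3ccccc3F)CC1)C(=O)OC2` gives > 50000 nM as a limit
Compound 2 `COC(=O)CC/C(C)=C/Cc1c(OC)c(C)c2c(c1OCC#CCN1CCN(C(=O)C3COc4ccccc4O3)CC1)C(=O)OC2` gives > 50000 nM as a limit

In a functional assay on FaDu cells (Homo sapiens) for inhibition, read by sulforhodamine B assay (a higher number here means a weaker inhibitor, a lower number a stronger inhibitor), compound 2 stands at > 50000 nM, which is a limit and not a number. Compound 3 `COC(=O)CC/C(C)=C/Cc1c(OC)c(C)c2c(c1OCC#CCN1CCN(c3ccc(C)cc3)CC1)C(=O)OC2` differs from it as follows: 4-methylphenyl in place of (2,3-dihydro-1,4-benzodioxin-2-yl)carbonyl on an amine nitrogen in a ring. Among the compounds with values here, the one measured step, a step that the two limits leave unreadable from compound 1 to compound 2, has no readable size, and the limit of > 50000 nM in this assay, at which 2 of the 2 values shown sit, covers both values. The nearest measured relative is compound 1, with 2-fluorophenyl on that nitrogen, and compound 1 also reads > 50000 nM, again a limit. No step beyond the scatter is therefore expected, and the estimated change is a number no higher from compound 2 to compound 3 (the limit leaves the size open) in this assay. Compound 3 is expected near 50000 nM, within 20000 nM to 100000 nM, and will probably be reported only as a limit.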

Compound 3, half-maximal inhibitory concentration: > 50000 nM
Compound 3 ended at the assay's limit (the forecaster's own chance of this, stated with the estimate: 75%); the middle value sits exactly at the limit.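

No step can be read from compound 1, compound 2 or compound 3 in this assay, because each gives only a limit, and the same one: the limit of > 50000 nM in this assay, at which 3 of the 3 values shown sit. The compounds shown leave open how strongly any of them inhibits, and whether the group on the ring nitrogen matters at all.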